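The source may hold more compounds than are shown below. What is called first, only, known or untested is meant among the compounds shown, and "the series" means these compounds.

Measured compounds:
compound 1, `OCc1cc(F)cc(C2=NCCCC2)c1`: 80 nM
compound 2, `Oc1cccc(C2=NCCCC2)c1`: 680 nM

Of the compounds shown here, two on a shared core have been measured in an assay on HEK293 cells for displacement of a labelled ligand from Neuronal acetylcholine receptor; alpha3/beta4 (Homo sapiens), read by radioligand binding, with a stated time of 5 min; a higher number here means a weaker inhibitor, a lower number a stronger inhibitor. Compound 1 `OCc1cc(F)cc(C2=NCCCC2)c1` gives 80 nM in this assay. Compound 2 `Oc1cccc(C2=NCCCC2)c1` gives 680 nM in this assay. Going by the values given here, of the two numbers, compound 2 stands at the higher one; its only neighbour, compound 1, sits at a clearly lower number, and the gap lies beyond the usual scatter. Among the compounds with values here, since the two structures differ in more than one place, the values say only that compound 2 is the weaker of the pair.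

Compound 3 `Ic1cccc(C2=NCCCC2)c1` has not yet been measured in this assay. It differs from compound 2 in a single place: iodo in place of hydroxy on an aromatic carbon. Within the data shown here, no measured pair shows a step of this kind, so the direction cannot be read from the numbers at hand. Compound 1, at 80 nM, shows that a lower number is reachable on this core. A modest step toward a lower number is expected from compound 2 to compound 3, a 2.7-fold lower number from compound 2 to compound 3 (0.43 log units; beyond the scatter). Compound 3 is estimated at 250 nM in this assay, with a range from 60 nM to 1000 nM.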

Compound 3, inhibition constant: 4.7 nM
Estimate against measurement, compound 3: 53-fold (1.73 log units) above; measured number outside the range, below it.
By their numbers in this assay, from the lowest: compound 3; then compound 1; then compound 2.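

In this assay, going by these compounds alone, iodo in place of hydroxy gives a 140-fold lower number from compound 2 to compound 3 (2.16 log units; beyond the scatter) and so provides the only single-place comparison on the shared core, one that lies well beyond the scatter. It shows that the number in this assay depends strongly on what this aromatic carbon carries, meta to the group of 6 heavy atoms. It also shows that a hydroxy, with its hydrogen-bond donor and acceptor, is not required here for a low number, since iodo, which counts neither, stands at the lower one.

The compounds shown do not separate what iodo adds from what the loss of hydroxy removes, and a plain hydrogen, bromo, chloro, methyl or an amine on the same carbon would be needed to tell those apart. As far as these compounds go, it also remains open whether the step would carry over to a compound bearing the hydroxymethyl and fluoro groups of compound 1, and nothing at hand gives any measured basis for explaining the size of this step.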